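A few compounds are considered here, and "the series" means these few. Any claim that something is new, unique, unknown or untested is made for them only; others in the source may bear on it.

Compound 1, `CNc1nc(NC2(C#N)CCCCC2)nc(-n2ccnc2)n1`, in an in vitro assay on Sf21 cells for inhibition of high affinity 3',5'-cyclic-AMP phosphodiesterase 7A (Homo sapiens) (on this read-out lower numbers stand for stronger inhibition and higher numbers for weaker inhibition), gives 1050 nM.
Compound 2, `CNc1nc(NC2(C#N)CCCCC2)nc(N(C)C)n1`, is reported in this assay only as a limit, > 5000 nM.
Compound 3, `CNc1nc(NC2(C#N)CCCCC2)nc(-n2cnc(C#N)n2)n1`, is likewise reported only as a limit, > 5000 nM.

Going by the values given here, compound 1 therefore stands as the only measured number among the three, with the other two sitting at a limit, namely (the limit of > 5000 nM in this assay, at which 2 of the 3 values shown sit). Compound 4, `CNc1nc(C#N)nc(NC2(C#N)CCCCC2)n1`, differs from compound 1 by cyano in place of 1H-imidazol-1-yl on an aromatic carbon. Among the compounds with values here, two measured steps bear on this change, both replacing the same 1H-imidazol-1-yl group on the shared core: an at least 4.7-fold higher number from compound 1 to compound 2 (0.67 log units; beyond the scatter) and an at least 4.7-fold higher number from compound 1 to compound 3 (0.67 log units; beyond the scatter). Each of these replacements weakened inhibition at least modestly, so a cyano group entering at the same place is expected to weaken inhibition as well, in the direction of the limit, though the two limits leave the size of that weakening uncertain. For compound 4 the estimate in this assay is 4000 nM, between 1500 nM and 10000 nM. This amounts to an expected 3.8-fold higher number from compound 1 to compound 4 (0.58 log units; beyond the scatter).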

Compound 4, half-maximal inhibitory concentration: > 1000 nM
Compound 4: no number, only a limit (the forecaster's own chance of this, stated with the estimate: 45%); the middle value lies beyond the limit too.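

Compound 4 is reported in this assay only as a limit, > 1000 nM. Going by these compounds alone, no step linking compound 4 to compound 1, compound 2 or compound 3 can be read from it. The compounds shown leave open how far, and in which direction, cyano in place of 1H-imidazol-1-yl shifts inhibition.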